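Cyclohexyl for methylpyridyl on the shared core

The source may hold more compounds than are shown below. What is called first, only, known or untested is meant among the compounds shown, and "the series" means these compounds.

Compound 1 `CC#C[C@@H](Cc1nnn[nH]1)c1ccc(OCc2ccc3scc(-c4cccnc4C)c3c2)cc1` is tested in a functional assay on cells for agonist activity at Free fatty acid receptor 1 (Rattus norvegicus), read by FLIPR and calcium flux (a lower number here means that less compound is needed, a higher number that more compound is needed for the effect), and gives 20 nM, which places it second highest of the three numbers in hand. Compound 2 `CC#C[C@@H](Cc1nnn[nH]1)c1ccc(OCc2ccc3scc(-c4ccc(OCCCS(C)(=O)=O)cc4C)c3c2)cc1` gives 9 nM, a lower number beyond the scatter; compound 3 `CC#C[C@@H](Cc1nnn[nH]1)c1ccc(OCc2cc(Cl)c3scc(-c4ccccc4C)c3c2)cc1` gives 108 nM, a higher number also beyond the scatter. Among the measured compounds shown here, the two neighbours thus differ from compound 1 in several places at once, and no single-point step between measured compounds is available to guide the next change.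

Compound 4 `CC#C[C@@H](Cc1nnn[nH]1)c1ccc(OCc2ccc3scc(C4CCCCC4)c3c2)cc1` differs from compound 1 by cyclohexyl in place of 2-methylpyridin-3-yl on an aromatic carbon. The aromatic ring with one nitrogen and its methyl is replaced by a saturated carbon ring of similar size, so the hydrogen-bond acceptor counted under that change is lost. With no measured step of this kind in the series, the expectation rests on compound 1 alone: a modest rise in the number, of a size that may or may not clear the scatter, seems most likely. The step of a 2.0-fold higher number from compound 1 to compound 4 (0.30 log units; within the scatter) is expected to be small and upward. For compound 4 the estimate is 40 nM, with a range from 12 nM to 130 nM.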

Compound 4, half-maximal effective concentration: 16 nM
Compound 4: middle estimate off by 2.5-fold (0.40 log units), on the high side; low and high end bracket the measured number.
By their numbers in this assay, from the lowest: compounds 2, 4 and 1 (each within the scatter of the next, the first and the last beyond it); then compound 3.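

In this assay, cyclohexyl in place of 2-methylpyridin-3-yl, on an aromatic carbon of the five-membered ring two ring bonds from the ring sulfur, gives a 1.3-fold lower number from compound 1 to compound 4 (0.10 log units; within the scatter). Among the compounds shown here, this is the first single-point step, and it shows that, on the core of compound 1, this position can carry a six-membered non-aromatic ring of carbon only with no change beyond the scatter. For this pair, neither the aromatic ring nor the hydrogen-bond acceptor counted in 2-methylpyridin-3-yl is needed to keep the number in this range.

Still open, on these data alone, is what a smaller ring such as cyclopropyl, or a ring with an amine such as piperidin-4-yl, would give at this position. The data on hand offer no explanation for how closely these two groups match.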